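The source may report more compounds than this note shows. Statements on the series, on what has been measured and on what is new or still open speak of the compounds shown alone.

Measured in a functional assay on A549 cells (Homo sapiens) for antiproliferative activity, read by sulforhodamine B assay, with a stated time of 72 h; on this read-out higher numbers stand for weaker inhibition and lower numbers for stronger inhibition:
Compound 1 `COc1cc2occ(-c3csc4ccccc34)c(=O)c2c(OC)c1O`: > 10000 nM
Compound 2 `O=C(/C=C/c1csc2ccccc12)c1cc(F)ccc1O`: 7100 nM

Compound 1 gives > 10000 nM in this assay, and this is a limit of the assay, not a number. Going by the values given here, compound 2 therefore holds the only true number in the set, 7100 nM, and the rest of the record amounts to the limit of > 10000 nM in this assay, at which 1 of the 2 values shown sits. With one number and one limit, the two compounds offer no ladder of values on which to place compound 2.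

The next compound is compound 3 `CC(C)Oc1ccc(O)c(C(=O)/C=C/c2csc3ccccc23)c1`. It keeps the frame of compound 2 and carries isopropoxy in place of fluoro on an aromatic carbon, para to a hydroxy group: isopropoxy in place of fluoro on an aromatic carbon. Among the compounds with values here, no step between measured compounds shows what a change at this place does. Within the data shown here, the only anchor is compound 2 at 7100 nM, so no step beyond the scatter is expected in this assay, in either direction. The expected change is a 1.2-fold lower number from compound 2 to compound 3 (0.07 log units; within the scatter). For compound 3 the estimated value is 6000 nM, with an expected range from 2000 nM to 18000 nM.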

Compound 3, half-maximal inhibitory concentration: 6400 nM
Beside the measured number, compound 3's estimate is 1.1-fold (0.03 log units) below it, and the stated range covers the measured number.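

In this assay, going by these compounds alone, the change from fluoro to isopropoxy, on an aromatic carbon para to a hydroxy group, gives the first step in this set that can be read at this place: a 1.1-fold lower number from compound 2 to compound 3 (0.05 log units; within the scatter). The position thus takes a group of 4 heavy atoms, including a hydrogen-bond acceptor, in place of a single fluorine atom, and compound 2 and compound 3 remain within the scatter of each other. None of the evidence at hand bears on this step, so the data give no account of why the two compounds match.

Going by these compounds, the two groups compared here are both neutral, so it remains open whether an amine or a carboxylic acid at this place, or a longer chain such as hexyloxy, would give a step beyond the scatter. On these data alone, it also remains open whether replacing the hydroxy group with methoxy would leave the number within the scatter, since this one step says nothing about that neighbouring group.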